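The source may hold more compounds than are shown below. What is called first, only, known or untested is meant among the compounds shown, and "the series" means these compounds.

Of the compounds shown here, three have been measured in an assay on RBL-1 cells for inhibition of Polyunsaturated fatty acid 5-lipoxygenase (Rattus norvegicus); a higher number here means a weaker inhibitor, a lower number a stronger inhibitor. Compound 1 `CCc1c(N(O)/C=C\C(=O)c2ccc3ccccc3c2)ccc2ccccc12` gives 750 nM. Compound 2 `O=C(/C=C\N(O)Cc1ccccc1)c1ccc2ccccc2c1` gives 1600 nM. Compound 3 `O=C(/C=C\N(O)Cc1ccc(-c2ccccc2)cc1)c1ccsc1` gives 3000 nM. On these numbers compound 3 is set apart from compound 1, the gap between them lying beyond the usual scatter of the measurement, whereas the numbers of compound 3 and compound 2 lie within that scatter of each other, so nothing can be said about their order.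

Compound 4 `O=C(/C=C\N(O)Cc1ccc(-c2ccccc2)cc1)c1ccco1` is built from compound 3 by one change: furan-2-yl in place of thiophen-3-yl on a carbonyl carbon. Within the data shown here, no pair among the measured compounds differs in this way, so there is no measured step to lean on; the rings leaving and entering are both small five-membered aromatic rings with one hetero atom and the same count of donors and acceptors. The expected step is no change at the digits printed from compound 3 to compound 4 (within the scatter), none beyond the scatter. Compound 4 is therefore estimated to give 3000 nM in this assay, with a likely range from 1000 nM to 9000 nM.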

Compound 4, half-maximal inhibitory concentration: 3100 nM
Beside the measured number, compound 4's estimate is 1.0-fold (0.01 log units) below it, and the stated range covers the measured number.
By their numbers in this assay, from the lowest: compound 1; then compounds 2, 3 and 4 (each within the scatter of the next).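

In this assay, replacing thiophen-3-yl with furan-2-yl on a carbonyl carbon gives a 1.0-fold higher number from compound 3 to compound 4 (0.01 log units; within the scatter). Among these compounds, this is the first step that can be read between two compounds differing in one place, and it shows that, with the rest of compound 3 kept the same, these two rings cannot be told apart in this measurement. The change swaps sulfur for oxygen and also moves the ring's point of attachment, yet the step as a whole stays within the scatter, although the two changes are not seen separately here.

As far as these compounds go, it remains open whether a phenyl ring, an amine or a longer alkyl chain on the same carbonyl carbon would also leave the number in place. Nothing available gives a reason why these two rings match.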